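This account rests on a few compounds, and the source may have more. Where it says the series, first, only, none or still open, it means among the compounds named here.

Compound 1 `O=C(Nc1cc(C(F)(F)F)cc(C(F)(F)F)c1)c1cnc(C(F)(F)F)nc1Cl`: > 10000 nM
Compound 2 `CCc1nc(Cl)ncc1C(=O)Nc1cc(C(F)(F)F)cc(C(F)(F)F)c1`: 400 nM
Compound 3 `Cc1cc(C(=O)Nc2cc(C(F)(F)F)cc(C(F)(F)F)c2)nc(Cl)n1`: > 10000 nM

In an assay on Jurkat cells for activation of nuclear factor NF-kappa-B complex (Homo sapiens) (on this read-out lower numbers stand for stronger inhibition and higher numbers for weaker inhibition), compound 1 gives > 10000 nM, which is a limit of the assay rather than a number. Compound 3 likewise sits at its limit with > 10000 nM. Only compound 2, with 400 nM, gives a measured number. So compound 1 stands at the limit of > 10000 nM in this assay, at which 2 of the 3 values shown sit, not at a value that can be ordered against others. Compound 4 `O=C(Nc1cc(C(F)(F)F)cc(C(F)(F)F)c1)c1cnc(C(F)(F)F)nc1C(F)(F)F` differs from compound 1 by trifluoromethyl in place of chloro on an aromatic carbon. Going by the values given here, no measured pair shows this change. Because the limit of > 10000 nM in this assay, at which 2 of the 3 values shown sit, already covers compound 1, the expected step that the limit leaves unreadable from compound 1 to compound 4 is small, within the scatter and without clear direction. Compound 4 is therefore expected to give about 15000 nM, between 3000 nM and 50000 nM, most likely again reported as a limit.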

Compound 4, half-maximal inhibitory concentration: > 10000 nM
Compound 4 gave a limit, no number; the forecaster's own chance of this, stated with the estimate: 70%; the middle value is on the limit's open side.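

Going by these compounds alone, compound 1 and compound 4 are both reported only as limits, so no step between them can be read: the limit of > 10000 nM in this assay, at which 3 of the 4 values shown sit. The compounds shown leave open how far trifluoromethyl in place of chloro on an aromatic carbon shifts inhibition, or in which direction.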